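This account rests on a few compounds, and the source may have more. Where it says the series, first, only, none or still open, it means among the compounds named here.

Of the compounds shown here, two that share one core have been measured in an assay on brain for displacement of a labelled ligand from Adrenergic receptor alpha-1 (Rattus norvegicus); on this read-out lower numbers stand for stronger inhibition and higher numbers for weaker inhibition. Compound 1 `CCN(CC)c1cc(N)c2cc(OC)c(OC)cc2n1` gives 2.93 nM in this assay. Compound 2 `C=CCNC(=O)N1CCN(c2cc(N)c3cc(OC)c(OC)cc3n2)CC1` gives 0.29 nM in this assay, which is the lower of the two numbers; compound 1 stands clearly above it, by a gap that lies beyond the usual scatter.

Compound 3 `COc1cc2nc(N3CCN(C(=O)Nc4ccccc4)CC3)cc(N)c2cc1OC` is the next compound to be measured. It differs from compound 2 in one place, phenyl in place of allyl on an amide-type nitrogen, with the carbonyl carbon as that nitrogen's other neighbour. Among the compounds with values here, no measured pair shows this particular change, so its effect in this assay is unknown from the data at hand. The expected step is a 1.4-fold higher number from compound 2 to compound 3 (0.14 log units; within the scatter), a small movement that is not expected to reach beyond the scatter. For compound 3 the estimate in this assay is 0.4 nM, with a range from 0.1 nM to 1.5 nM.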

Compound 3, inhibition constant: 0.34 nM
Compound 3: middle estimate off by 1.2-fold (0.07 log units), on the high side; measured number inside the range.
By their numbers in this assay, from the lowest: compounds 2 and 3 (each within the scatter of the next); then compound 1.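

In this assay, within the data shown here, putting phenyl in place of allyl on the amide-type nitrogen, with the carbonyl carbon as that nitrogen's other neighbour, gives a 1.2-fold higher number from compound 2 to compound 3 (0.07 log units; within the scatter) and so gives the first measured step at this position. Phenyl brings a six-membered aromatic ring of carbon only and 6 heavy atoms where allyl has no ring and 3 heavy atoms, yet the numbers of this one pair cannot be told apart. Nothing at hand bears on the reason for this result.

The pair leaves open whether a longer chain, a cyclohexyl ring or a benzyl group on this nitrogen would also stay within the scatter of compound 2. It also leaves open what an amine or a carboxylic acid on the phenyl ring of compound 3 would do to the number.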